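A few compounds are considered here, and "the series" means these few. Any claim that something is new, unique, unknown or untested is made for them only; others in the source may bear on it.

Measured so far in a functional assay on HeLa cells (Homo sapiens) for antiproliferative activity, read by MTT assay, with a stated time of 48 h; on this read-out lower numbers stand for stronger inhibition of growth and higher numbers for weaker inhibition of growth:
compound 1 `COc1ccc(/C=C2\Cc3c(cc(OC)c(OC)c3OC)C2=O)cc1[N+](=O)[O-]` gives 790 nM.
compound 2 `COc1ccc(/C=C2\Cc3c(cc(OC)c(OC)c3OC)C2=O)cc1` gives 485 nM.
compound 3 `COc1ccc(/C=C2\Cc3cc(OC)c(OC)c(OC)c3C2=O)cc1[N+](=O)[O-]` reaches only the limit of this assay, > 10000 nM, which is not a number.

Compounds 1 and 2 share one core; compound 3 has the same atoms joined differently, and the difference between the two cores is not broken down here. The change hydrogen in place of nitro on an aromatic carbon gave a 1.6-fold lower number from compound 1 to compound 2 (0.21 log units; within the scatter). The same change, (hydrogen in place of nitro on an aromatic carbon), leads from compound 3 to compound 4 `COc1ccc(/C=C2\Cc3cc(OC)c(OC)c(OC)c3C2=O)cc1`, not yet measured in this assay. Compound 3 stands at the limit of > 10000 nM in this assay, at which 1 of the 3 values shown sits. Because of a 1.6-fold lower number from compound 1 to compound 2 (0.21 log units; within the scatter) the change is expected to move compound 4 little, so the expected step is a number no higher from compound 3 to compound 4 (the limit leaves the size open). Compound 4 is therefore estimated at 10000 nM, between 3000 nM and 30000 nM, with a substantial chance that this assay again reports only a limit.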

Compound 4, concentration for 50% growth inhibition: > 10000 nM
Compound 4 ended at the assay's limit (the forecaster's own chance of this, stated with the estimate: 55%); the middle value lies on the limit itself.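

In this assay, for the compounds shown here, compound 3 and compound 4 both end at a limit of the assay, not a number, so no step between them can be read. The compounds shown leave open what hydrogen in place of nitro does on the core of compound 3.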